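Tetrahydroquinoline-carboxamide anilides: hydroxy versus trifluoromethyl on the anilide

The source may hold more compounds than are shown below. What is called first, only, known or untested is meant among the compounds shown, and "the series" means these compounds.

Measured so far:
compound 1 `CC(=O)N1c2ccccc2CCC1C(=O)Nc1ccccc1O` gives 50700 nM
compound 2 `O=C(Nc1ccccc1C(F)(F)F)C1CCc2ccccc2N1` gives 57600 nM
compound 3 `O=C(Nc1ccccc1C(F)(F)F)C1CCc2ccccc2N1C(=O)c1cccc(Cl)c1` gives 526 nM

All three numbers come from a functional assay on ACHN cells (Homo sapiens) for cytotoxicity, read by sulforhodamine B assay, with a stated time of 72 h; on this read-out higher numbers stand for weaker inhibition of growth and lower numbers for stronger inhibition of growth. Within the data shown here, compound 2 has the highest of the three numbers; compound 1 lies within the scatter of compound 2, and compound 3 is far away, a 110-fold lower number from compound 2 to compound 3 (2.04 log units; beyond the scatter), so the only step that is beyond the scatter is the one that puts a (3-chlorophenyl)carbonyl on the ring nitrogen.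

Compound 4 `O=C(Nc1ccccc1O)C1CCc2ccccc2N1` differs from compound 2 in the anilide only: hydroxy in place of trifluoromethyl on an aromatic carbon. Among the measured compounds shown here, no measured step touches this position directly. What the data do show is that compound 1, which carries the hydroxy anilide together with an acetyl on the ring nitrogen, and compound 2, which carries the trifluoromethyl anilide with a free ring nitrogen, sit within the scatter of each other. Two things change between those two compounds, so they do not isolate the anilide swap, but they give no sign that the hydroxy anilide by itself moves this assay far in either direction.

The step from compound 2 to compound 4 is therefore expected to be a 1.2-fold lower number from compound 2 to compound 4 (0.06 log units; within the scatter), that is, no step beyond the scatter. Compound 4 is estimated at 50000 nM, with a range from 15000 nM to 160000 nM.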

Compound 4, concentration for 50% growth inhibition: 3990 nM
The estimate for compound 4 lay 13-fold (1.10 log units) above the measured number; measured number outside the range, below it.
By their numbers in this assay, from the lowest: compound 3; then compound 4; then compounds 1 and 2 (each within the scatter of the next).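

Working notes: in this assay the anilide position does respond when the ring nitrogen is free, with hydroxy in place of trifluoromethyl on the aromatic carbon giving a 14-fold lower number from compound 2 to compound 4 (1.16 log units; beyond the scatter), so the swap is not neutral on this core. With the hydroxy anilide held fixed, the ring nitrogen also matters: hydrogen in place of acetyl gives a 13-fold lower number from compound 1 to compound 4 (1.10 log units; beyond the scatter), which means that the closeness of compound 1 and compound 2 conceals two separate steps, each beyond the scatter, running in opposite directions through compound 4. No measurement at hand accounts for either step.

As far as these compounds go, compound 3 carries the (3-chlorophenyl)carbonyl only together with the trifluoromethyl anilide, so it remains open whether hydroxy in place of trifluoromethyl would give a step of similar direction and size on a ring nitrogen bearing that group. Also open, from the compounds shown here alone, is how an amine or a carboxylic acid on the same aromatic carbon would compare with hydroxy and trifluoromethyl in this growth read-out.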